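One Trifluoromethyl Fewer: What to Expect for Compound 3

The compounds below may be only part of what the source reports. "The series", "measured", "known", "first", "only" and "open" are said of these compounds alone.

Compound 1 `COc1cc(Cl)cc(-c2nn(-c3cccc(NC(=O)Nc4ccc(Cl)c(C(F)(F)F)c4)c3)cc2-c2ccncc2)c1`: 1.88%
Compound 2 `COc1cc(Cl)cc(-c2nn(-c3cccc(NC(=O)Nc4cc(C(F)(F)F)cc(C(F)(F)F)c4)c3)cc2-c2ccncc2)c1`: -22%

Both compounds were tested in a functional assay on CCRF-CEM cells (Homo sapiens) for inhibition, read by sulforhodamine B assay, with a stated time of 48 h, tested at 10 uM; a higher number here means a weaker effect of the compound at the concentration tested, a lower number a stronger effect. Compound 2 holds the lowest of the two numbers, and its nearest neighbour, compound 1, lies higher by a gap beyond the usual scatter, so compound 2 shows the stronger effect of the pair at this concentration.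

Compound 3 `COc1cc(Cl)cc(-c2nn(-c3cccc(NC(=O)Nc4cccc(C(F)(F)F)c4)c3)cc2-c2ccncc2)c1` is still to be measured in this assay. It differs from compound 2 in one place: hydrogen in place of trifluoromethyl on an aromatic carbon. For the measured compounds named here, no step between two measured compounds mirrors this change, so the expectation rests only on where compound 2 and compound 1 stand. Losing one of the two trifluoromethyl groups is expected to move the number upward, toward a weaker effect, by a step of a number 32 percentage points higher from compound 2 to compound 3 (beyond the scatter) that lies beyond the scatter. Compound 3 is therefore estimated at 10%, with a plausible range from -15% to 35%.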

Compound 3, a percentage reported as activity, at one concentration (the size of the read-out at that concentration, not a potency): 3.34%
Beside the measured number, compound 3's estimate is 6.7 percentage points above it; the range from low to high includes it.
By their numbers in this assay, from the lowest: compound 2; then compounds 1 and 3 (each within the scatter of the next).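

In this assay, the change on this aromatic carbon counts: hydrogen in place of trifluoromethyl gives a number 25.3 percentage points higher from compound 2 to compound 3 (beyond the scatter), a modest step beyond the scatter, so the second trifluoromethyl group goes with the stronger effect at this concentration. The same ring does not respond to every removal, since hydrogen in place of chloro on another aromatic carbon gives a number 1.5 percentage points higher from compound 1 to compound 3 (within the scatter), which is within the scatter, so compound 1 and compound 3 cannot be told apart. No measurement shown here explains why one replacement registers and the other does not.

On these data alone, whether the effect needs trifluoromethyl itself remains open, as a nitrile or an amine on the same carbon could show. These readings also come from a single concentration, so they say nothing about potency.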